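A few compounds are considered here, and "the series" means these few. Any claim that something is new, unique, unknown or untested is made for them only; others in the source may bear on it.

Of the compounds shown here, three that share one core have been tested in a functional assay on CCRF-CEM cells (Homo sapiens) for cytotoxicity, read by MTT assay, with a stated time of 72 h; a higher number here means a weaker inhibitor of growth, a lower number a stronger inhibitor of growth. Compound 1 `CCCOC(=O)Nc1ccc([Se]C#N)cc1` gives 38400 nM and compound 2 `C=CCOC(=O)Nc1ccc([Se]C#N)cc1` gives 38100 nM; the step of a 1.0-fold lower number from compound 1 to compound 2 (0.00 log units; within the scatter) shows that altering the chain on the carbamate left the number where it was. Compound 3 `N#C[Se]c1ccc(NC(=O)OCc2ccc([N+](=O)[O-])cc2)cc1` gives 38300 nM, the second highest of the three numbers, yet within the scatter of both others. Compound 4 `N#C[Se]c1ccc(NC(=O)OCc2ccccc2)cc1` differs from compound 3 by hydrogen in place of nitro on an aromatic carbon. Among the measured compounds shown here, no measured step touches this ring position; the only measured step, a 1.0-fold lower number from compound 1 to compound 2 (0.00 log units; within the scatter), concerns the chain and was flat. Accordingly the estimated step is a 1.0-fold lower number from compound 3 to compound 4 (0.00 log units; within the scatter), nothing beyond the scatter. Compound 4 is expected to give about 38000 nM, within a range from 19000 nM to 76000 nM.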

Compound 4, concentration for total growth inhibition: 48400 nM
Compound 4: middle estimate off by 1.3-fold (0.11 log units), on the low side; low and high end bracket the measured number.
By their numbers in this assay, from the lowest: compounds 2, 3, 1 and 4 (each within the scatter of the next).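

In this assay, this aromatic carbon now has its first measured change, and hydrogen in place of nitro stays within the scatter (a 1.3-fold higher number from compound 3 to compound 4 (0.10 log units; within the scatter)). The unsubstituted phenyl group also stays within the scatter of the two shorter chains, both against vinyl (a 1.3-fold higher number from compound 2 to compound 4 (0.10 log units; within the scatter)) and against ethyl (a 1.3-fold higher number from compound 1 to compound 4 (0.10 log units; within the scatter)). No supporting data explain why these numbers sit so close together. As far as these compounds go, whether an amine or a carboxylic acid on this aromatic carbon would move the number stays open, as does the effect of a longer chain on the carbamate oxygen.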